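The compounds below may be only part of what the source reports. "The series", "measured", "known", "first", "only" and "open" are said of these compounds alone.

Measured in an ADME assay on microsomes from liver (Mus musculus) for metabolic stability; on this read-out lower numbers stand for slow clearance and higher numbers for fast clearance:
compound 1 `CCOc1cc2[nH]c(Cc3nn(CC(=O)N4CCOCC4)c(=O)c4ccccc34)nc2cc1Cl`: 817 mL/min/kg
compound 2 `CCn1nc(CC(=O)Nc2ccc(OC(F)(F)F)c(Cl)c2)c2ccccc2c1=O`: 81.7 mL/min/kg

Compound 2 holds the lower of the two numbers, and its gap to compound 1 lies beyond the scatter. Among the compounds with values here, no step between measured compounds that differ in one place is available yet. Compound 3 `O=C(Cc1nn(CC(=O)N2CCOCC2)c(=O)c2ccccc12)Nc1ccc(OC(F)(F)F)c(Cl)c1` departs from compound 2 by (morpholin-4-yl)carbonyl in place of methyl on a saturated chain carbon bound to an aromatic nitrogen. Within the data shown here, the only measured compound carrying (morpholin-4-yl)carbonyl is compound 1 at 817 mL/min/kg, so a moderate rise in this assay is expected. This expectation rests on a single compound, so the range stays wide. The expected move is a 2.0-fold higher number from compound 2 to compound 3 (0.29 log units; within the scatter), towards faster clearance. The estimate for compound 3 is 160 mL/min/kg, with an expected range of 70 mL/min/kg to 400 mL/min/kg.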

Compound 3, clearance: 11900 mL/min/kg
The estimate for compound 3 lay 74-fold (1.87 log units) below the measured number; the whole stated range lies below it.
By their numbers in this assay, from the lowest: compound 2; then compound 1; then compound 3.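

Within the data shown here, on a saturated chain carbon bound to an aromatic nitrogen, (morpholin-4-yl)carbonyl in place of methyl gives the first one-place comparison, and in this assay it produces a 150-fold higher number from compound 2 to compound 3 (2.16 log units; beyond the scatter). This position is therefore far from silent: with the rest of the structure unchanged, this single change moves the read-out well beyond the scatter, towards faster clearance. Nothing available explains the size or direction of this step.

The compounds shown leave open whether the rise follows the morpholine ring, the carbonyl or simply the larger group, so a piperidin-1-ylcarbonyl group, a dimethylaminocarbonyl group or a propyl chain at this place would separate these readings. Going by these compounds, it also remains open whether a carboxylic acid here would behave alike, and whether the step holds on the core of compound 1.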